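A few compounds are considered here, and "the series" means these few. Any claim that something is new, unique, unknown or untested is made for them only; others in the source may bear on it.

In an ADME assay on Vero cells (Chlorocebus sabaeus) for cytotoxicity, read by sulforhodamine B assay, with a stated time of 3 days (on this read-out lower numbers stand for higher toxicity in this test and higher numbers for lower toxicity in this test), compound 1 `CC1=C(C(=O)Nc2ccc(Cl)cc2)C(c2ccccc2)C(C(=O)Nc2ccc(Cl)cc2)=C(C)N1` gives 15 ug/mL, compound 2 `COc1ccc(NC(=O)C2=C(C)NC(=O)NC2c2ccc(OC)cc2)cc1` gives 158 ug/mL and compound 3 `COc1ccc(NC(=O)C2=C(C)NC(=S)NC2c2ccco2)cc1` gives 230 ug/mL. Compound 2 thus stands level with compound 3, within the scatter, and clearly apart from compound 1, whose number is lower. Compound 4 `COc1ccc(NC(=O)C2=C(C)NC(=O)NC2C/C=C/c2ccccc2)cc1` departs from compound 2 in one place: on a saturated ring carbon, 3-phenylprop-2-en-1-yl replaces 4-methoxyphenyl (3-phenylprop-2-en-1-yl in place of 4-methoxyphenyl on a saturated ring carbon). Among the compounds with values here, no pair of measured compounds differs in one place alone, so the data offer no direct guide to this change. A small downward move in this assay, none beyond the scatter, is expected. The estimated step is a 1.4-fold lower number from compound 2 to compound 4 (0.16 log units; within the scatter). Compound 4 is estimated at 110 ug/mL, with an expected range of 45 ug/mL to 260 ug/mL.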

Compound 4, half-maximal cytotoxic concentration: 15 ug/mL
The estimate for compound 4 lay 7.3-fold (0.87 log units) above the measured number, outside the stated range (below it).
By their numbers in this assay, from the lowest: compounds 1 and 4 (each within the scatter of the next); then compounds 2 and 3 (each within the scatter of the next).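

In this assay the saturated ring carbon next to the ring nitrogen proves sensitive: 3-phenylprop-2-en-1-yl in place of 4-methoxyphenyl gives an 11-fold lower number from compound 2 to compound 4 (1.02 log units; beyond the scatter), a large step. Within the data shown here, this is the first change in one place alone to be read here, and it shows that the group on this carbon can by itself move the number this far. Nothing at hand explains the step. The compounds shown leave open whether the double bond, the chain or the loss of the methoxy group carries it. As far as these compounds go, how a saturated 3-phenylpropyl chain or an unsubstituted phenyl would read on this carbon also stays open.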